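Methyl on the Hydroxy Oxygen: What to Expect Next

This account rests on a few compounds, and the source may have more. Where it says the series, first, only, none or still open, it means among the compounds named here.

Two measured compounds share one core and differ in two places at once, so no single step between them is shown. Compound 1 `COc1cc(Cl)cc(-c2nn(-c3cccc(NC(=O)c4cccc(C(F)(F)F)c4)c3)cc2-c2ccncc2)c1` gives 74.5% in a functional assay on UACC-62 cells (Homo sapiens) for inhibition, read by sulforhodamine B assay, with a stated time of 48 h, tested at 10 uM; a higher number here means a weaker effect of the compound at the concentration tested, a lower number a stronger effect. Compound 2 `O=C(Nc1cccc(-n2cc(-c3ccncc3)c(-c3cc(O)cc(Cl)c3)n2)c1)c1cc(C(F)(F)F)cc(C(F)(F)F)c1` gives 69.3% in this assay, the lower of the two numbers, but its gap to compound 1 lies within the scatter, so the two cannot be put in order. Compound 3 `COc1cc(Cl)cc(-c2nn(-c3cccc(NC(=O)c4cc(C(F)(F)F)cc(C(F)(F)F)c4)c3)cc2-c2ccncc2)c1` has not been measured. It differs from compound 2 in one place: methyl in place of hydrogen on an oxygen on an aromatic ring. For the measured compounds named here, no measured pair shows this change on its own, so nothing points to a direction. The step from compound 2 to compound 3 is estimated as a number 2.7 percentage points higher from compound 2 to compound 3 (within the scatter), which is expected to stay within the scatter. Compound 3 is therefore expected to give about 72% in this assay, likely between 55% and 90%.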

Compound 3, a percentage reported as activity, at one concentration (the size of the read-out at that concentration, not a potency): 81.4%
Estimate against measurement, compound 3: 9.4 percentage points below, within the range that was stated.
By their numbers in this assay, from the lowest: compounds 2, 1 and 3 (each within the scatter of the next, the first and the last beyond it).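

Putting methyl on the hydroxy oxygen now has a step of its own: in this assay, the change from hydroxy to methoxy gives a number 12.1 percentage points higher from compound 2 to compound 3 (beyond the scatter), so at the concentration tested this oxygen is a place where a single added carbon can weaken the effect. The added trifluoromethyl on an aromatic carbon, by contrast, gives a number 6.9 percentage points higher from compound 1 to compound 3 (within the scatter), so with methoxy in place its effect cannot be told apart from no change. Nothing shown here explains why the methyl matters at this oxygen.

The compounds shown leave open whether hydroxy to methoxy gives a similar step in compounds carrying a single trifluoromethyl. They also leave open how a longer chain on this oxygen, such as ethyl, or an amine in place of the hydroxy would read.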